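Chain extension on the core of compound 2

A few compounds are considered here, and "the series" means these few. Any claim that something is new, unique, unknown or untested is made for them only; others in the source may bear on it.

Compound 1 `CCc1nn(CCCN2CCN(c3ccc(C)cc3)CC2)c(=O)c(N)c1C(C)=O` carries an acetyl group on an aromatic carbon; in a functional assay on the whole organism (Abdomen, strain Swiss) for inhibition, with Mus musculus as the target, with stated times of 30 min, 10 min and 5 min, at a dose of 20 mg/kg by the oral route (on this read-out lower numbers stand for a weaker effect and higher numbers for a stronger effect at the one dose given), compound 1 gives 42%. Compound 2 `C=Cc1c(CC)nn(CCCN2CCN(c3ccc(C)cc3)CC2)c(=O)c1N` gives 0% in this assay, the lowest of the two numbers shown, and the only measured step, a number 42 percentage points lower from compound 1 to compound 2 (beyond the scatter), is one of vinyl in place of acetyl on an aromatic carbon. Compound 3 `C=Cc1c(CCC)nn(CCCN2CCN(c3ccc(C)cc3)CC2)c(=O)c1N` differs from compound 2 by methyl in place of hydrogen on a saturated chain carbon, two bonds along the chain from an aromatic carbon. Among the measured compounds shown here, no measured step concerns this place: the step between compound 1 and compound 2 alters a group on an aromatic carbon, not the saturated chain, so it offers no guidance on size or direction here. Nothing in the data points to a change beyond the scatter. Compound 2 already stands at the bottom of the read-out. Compound 3 is therefore expected to stay close, with a number 3 percentage points higher from compound 2 to compound 3 (within the scatter) as the estimated step. The estimate for compound 3 in this assay is 3%, with a range from 0% to 15%.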

Compound 3, a percentage reported as inhibition, in the whole organism at one dose (the size of the read-out at that dose, not a potency): 7%
For compound 3 the middle estimate is 4 percentage points below the measured one; measured number inside the range.
By their numbers in this assay, from the lowest: compounds 2 and 3 (each within the scatter of the next); then compound 1.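

Methyl in place of hydrogen on a saturated chain carbon, two bonds along the chain from an aromatic carbon, turns ethyl into propyl, and this assay gives a number 7 percentage points higher from compound 2 to compound 3 (within the scatter) for this change. Among the compounds shown here, this is the first reading at this place, and with vinyl kept on the aromatic carbon, the propyl chain is not separated from the ethyl chain on this read-out. No available measurement bears on the reason for this result.

From the compounds shown here alone, it remains open whether the same change from ethyl to propyl would read alike with acetyl on the aromatic carbon, where the shared core gives a clear effect. Also open, going by these compounds, is how a longer chain such as butyl, or a terminal amine on the chain, would read at this place.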